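The compounds below may be only part of what the source reports. "The series", "measured", "known", "first", "only" and "open" are said of these compounds alone.

Measured so far: compound 1 `Cc1cc(/C=C/C#N)cc(C)c1Oc1nc(Nc2ccc(CN3CCNCC3)cc2)nc2ccsc12` gives 3970 nM in an ADME assay on MT4 cells (Homo sapiens) for cytotoxicity, read by MTT assay, with a stated time of 5 days; a lower number here means that less compound is tolerated, a higher number that more compound is tolerated; compound 2 `Cc1cc(/C=C/C#N)cc(C)c1Oc1nc(Nc2ccc(CN3CCN(S(N)(=O)=O)CC3)cc2)nc2sccc12` gives > 217000 nM.

The value of compound 2 is a limit of the assay and not a number, so compound 2 stands at the most tolerated end of what has been seen here (the limit of > 217000 nM in this assay, at which 1 of the 2 values shown sits). Compound 3 `Cc1cc(/C=C/C#N)cc(C)c1Oc1nc(Nc2ccc(N3CCCC(NS(N)(=O)=O)C3)cc2)nc2sccc12` differs from compound 2 in one place: 3-(sulfamoylamino)piperidin-1-yl in place of (4-sulfamoylpiperazin-1-yl)methyl on an aromatic carbon. Within the data shown here, with no measured step between two compounds to lean on, compound 3 is expected to behave like compound 2, with no change beyond the scatter, and its half-maximal cytotoxic concentration is estimated at 180000 nM (40000 nM to 400000 nM), a step of an at least 1.2-fold lower number from compound 2 to compound 3 (0.08 log units; that floor lies within the scatter).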

Compound 3, half-maximal cytotoxic concentration: > 217000 nM
Compound 3 ended at the assay's limit; the forecaster's own chance of this, stated with the estimate: 60%; middle value at least 1.2-fold (0.08 log units) from the limit.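

In this assay, among these compounds, compound 2 and compound 3 both end at a limit and not at a number, so no step between them can be read. The compounds shown leave open how far past that limit either compound lies, and whether the exchanged groups differ at all.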